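Shifting a fluorophenyl substituent on a quinazoline-like scaffold

The compounds below may be only part of what the source reports. "The series", "measured", "known", "first", "only" and "open" are said of these compounds alone.

Compounds measured in a functional assay on MGC-803 cells (Homo sapiens) for inhibition, read by MTT assay, with a stated time of 72 h; on this read-out higher numbers stand for weaker inhibition and lower numbers for stronger inhibition:
compound 1 `C=CC(=O)Nc1cccc(NC(=O)CSc2nc(Nc3ccccc3Br)c3ccccc3n2)c1` gives 12800 nM
compound 2 `C=CC(=O)Nc1cccc(NC(=O)CSc2nc(Nc3cccc(F)c3)c3ccccc3n2)c1` gives 6250 nM
compound 3 `C=CC(=O)Nc1cccc(NC(=O)CSc2nc(Nc3cccc(OC)c3)c3ccccc3n2)c1` gives 24200 nM

Compound 3 sits at the top of the three numbers. Its separation from compound 1 is a 1.9-fold higher number from compound 1 to compound 3 (0.28 log units; within the scatter), a step within the scatter, whereas its separation from compound 2 is a 3.9-fold higher number from compound 2 to compound 3 (0.59 log units; beyond the scatter), a step beyond the scatter.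

Compound 4 `C=CC(=O)Nc1cccc(NC(=O)CSc2nc(Nc3ccc(F)cc3)c3ccccc3n2)c1` has not been measured in this assay. It differs from compound 3 in one place: 4-fluorophenyl in place of 3-methoxyphenyl on a nitrogen on an aromatic ring. Among the compounds with values here, two measured steps bear on this. The exchange of methoxy for fluoro on the same ring gave a 3.9-fold higher number from compound 2 to compound 3 (0.59 log units; beyond the scatter), so the reverse exchange should pull the number down. The move from 2-bromophenyl to 3-fluorophenyl gave a 2.0-fold lower number from compound 1 to compound 2 (0.31 log units; beyond the scatter), again favouring the fluorine-bearing ring. Compound 4 carries fluorine, but at a position no measured compound has shown, so the exact size is uncertain.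

Compound 4 is therefore expected to give a number below that of compound 3, estimated at 8000 nM with a range from 3000 nM to 25000 nM. This estimate corresponds to an expected step of a 3.0-fold lower number from compound 3 to compound 4 (0.48 log units; beyond the scatter).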

Compound 4, half-maximal inhibitory concentration: 8290 nM
Compound 4: middle estimate off by 1.0-fold (0.02 log units), on the low side, within the range that was stated.
By their numbers in this assay, from the lowest: compounds 2, 4, 1 and 3 (each within the scatter of the next, the first and the last beyond it).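

In this assay the 4-fluorophenyl group gives a second fluorine-bearing ring on this nitrogen, and the step from the 3-fluorophenyl group (a 1.3-fold higher number from compound 2 to compound 4 (0.12 log units; within the scatter)) lies within the scatter, so these two placings of the fluorine on the ring are not told apart by this read-out. The separation from 3-methoxyphenyl now rests on two fluorine-bearing rings rather than one, with a 2.9-fold lower number from compound 3 to compound 4 (0.47 log units; beyond the scatter) standing alongside the earlier 3.9-fold higher number from compound 2 to compound 3 (0.59 log units; beyond the scatter) and both steps lying beyond the scatter. The 2-bromophenyl group looks less clearly separated than it did, as a 1.5-fold lower number from compound 1 to compound 4 (0.19 log units; within the scatter) is within the scatter, while the earlier 2.0-fold lower number from compound 1 to compound 2 (0.31 log units; beyond the scatter) only just passed beyond it.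

No measured evidence accompanies these compounds to explain any of these steps. The compounds shown leave open whether an unsubstituted phenyl ring, a chlorophenyl ring or a phenyl ring carrying an amine on this nitrogen would group with the two fluorophenyl compounds or with the 3-methoxyphenyl compound.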